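The source may hold more compounds than are shown below. What is called first, only, known or untested is meant among the compounds shown, and "the series" means these compounds.

Compound 1 `Cc1cc(C)c(NC(=O)c2sccc2S(=O)(=O)Nc2onc(C)c2Cl)c(-c2ncco2)c1` gives 134000 nM
Compound 2 `Cc1cc(C)c(NC(=O)c2sccc2S(=O)(=O)Nc2onc(C)c2Cl)c(C(=O)C2CC2)c1` gives 108000 nM

In an in vivo ADME assay on the whole organism (plasma) for pharmacokinetics, with Rattus norvegicus as the target, at a dose of 50 mg/kg by the oral route (a lower number here means less compound in the circulation, a higher number more compound in the circulation at the dose given), compound 2 gives 108000 nM and stands within the scatter of compound 1. The change to compound 3 `CO/N=C(\C)c1cc(C)cc(C)c1NC(=O)c1sccc1S(=O)(=O)Nc1onc(C)c1Cl` is a group of 5 heavy atoms (3 carbon, 1 nitrogen, 1 oxygen; no ring) in place of a group of 5 heavy atoms (4 carbon, 1 oxygen; one three-membered non-aromatic ring of carbon only), on an aromatic carbon and the rest of the structure stays shared. Going by the values given here, only one measured step bears on this, a 1.2-fold lower number from compound 1 to compound 2 (0.09 log units; within the scatter) on that same aromatic carbon, where cyclopropylcarbonyl took the place of 1,3-oxazol-2-yl. Among the compounds with values here, no measured compound carries the entering group, so the evidence is thin and no step beyond the scatter is expected in this assay for this change. The expected step is a 1.1-fold lower number from compound 2 to compound 3 (0.03 log units; within the scatter) and no larger shift is foreseen. For compound 3 the estimated value is 100000 nM with an expected range from 45000 nM to 220000 nM in this estimate.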

Compound 3, maximal plasma concentration: 27800 nM
Compound 3: middle estimate off by 3.6-fold (0.56 log units), on the high side; the whole stated range lies above it.
By their numbers in this assay, from the lowest: compound 3; then compounds 2 and 1 (each within the scatter of the next).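

In this assay, this aromatic carbon proves sensitive to its substituent: the earlier swap stayed within the scatter, but the group with no ring gives a 3.9-fold lower number from compound 2 to compound 3 (0.59 log units; beyond the scatter) and a 4.8-fold lower number from compound 1 to compound 3 (0.68 log units; beyond the scatter). Both steps lie beyond the scatter, so compound 3 stands apart from the two compounds that carry a ring in this group. No measurement here accounts for this drop. From the compounds shown here alone, whether an acetyl group or an amine on this aromatic carbon would fall with compound 1 and compound 2 or with compound 3 stays open.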